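The source may hold more compounds than are shown below. What is called first, only, known or untested is meant among the compounds shown, and "the series" means these compounds.

Of the compounds shown here, two carrying the shared core have been measured. Compound 1 `CCOC(=O)C1CCN(Cn2nc(C(C)c3ccc(CC(C)C)cc3)oc2=S)CC1` gives 55.2% in a functional assay on the whole organism (strain Swiss albino) for inhibition, with Mus musculus as the target, in the hot plate test, with stated times of 15 s and 90 min, at a dose of 10 mg/kg by the oral route; on this read-out higher numbers stand for more inhibition at the one dose given (going by the name of the read-out) and lower numbers for less inhibition. Compound 2 `CC(C)Cc1ccc(C(C)c2nn(CN3CCN(c4ccc(Cl)cc4)CC3)c(=S)o2)cc1` gives 35.8% in this assay, the lowest of the two numbers; its gap to compound 1 is beyond the scatter. Compound 3 `CC(C)Cc1ccc(C(C)c2nn(CN3CCN(c4ccc([N+](=O)[O-])cc4)CC3)c(=S)o2)cc1` has not yet been measured in this assay. The change from compound 2 to compound 3 is nitro in place of chloro on an aromatic carbon. Among the measured compounds shown here, no step of this kind between measured compounds is available, so the two values already in hand give no guide to its size or direction. Resting on the structural change alone, the step of a number 2.2 percentage points higher from compound 2 to compound 3 (within the scatter) is expected to stay within the scatter, with no clear direction. For compound 3 the estimated value in this assay is 38%, with a range from 22% to 54%.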

Compound 3, a percentage reported as inhibition, in the whole organism at one dose (the size of the read-out at that dose, not a potency): 44.8%
Compound 3: the middle estimate sits 6.8 percentage points below what was measured; the measured number falls inside the stated range.
By their numbers in this assay, from the lowest: compounds 2 and 3 (each within the scatter of the next); then compound 1.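

In this assay the first step read at this place on the aromatic ring is a number 9 percentage points higher from compound 2 to compound 3 (within the scatter), so the change from 4-chlorophenyl to 4-nitrophenyl, para to a large group, does not separate the two compounds on this read-out. At this dose, this one pair therefore gives no sign that the exchange of chloro for nitro matters here, though a single pair sets no trend for the position. No measurement available here bears on why the two compounds read alike.

As far as these compounds go, it remains open how this place responds to groups of a different kind, such as an amine, a carboxylic acid or a methoxy group, or to a bare hydrogen. Also open, from the compounds shown here alone, is whether a longer chain at this place would stay within the scatter of these two compounds.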